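This account rests on a few compounds, and the source may have more. Where it says the series, first, only, none or still open, it means among the compounds named here.

Compound 1, `Clc1ccc(/C=N/Nc2nc3ccccc3nc2Cc2ccccc2)cc1`, in an assay on isolated protein for inhibition of Amine oxidase [flavin-containing] B (Homo sapiens), read by spectrophotometry (a lower number here means a stronger inhibitor, a higher number a weaker inhibitor), gives 84000 nM.
Compound 2, `C/C(=N\Nc1nc2ccccc2nc1Cc1ccccc1)c1ccccn1`, in this assay gives 980000 nM.
Compound 3, `Brc1cccc(/C=N/Nc2nc3ccccc3nc2Cc2ccccc2)c1`, in this assay gives 48000 nM.

Compound 3 has the lowest of the three numbers in this assay. Its nearest neighbour is compound 1: the step of a 1.8-fold lower number from compound 1 to compound 3 (0.24 log units; within the scatter) lies within the scatter, so the two cannot be ranked against each other. The gap to compound 2 is another matter: the step of a 20-fold lower number from compound 2 to compound 3 (1.31 log units; beyond the scatter) is large, and so is the related step of a 12-fold higher number from compound 1 to compound 2 (1.07 log units; beyond the scatter).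

Compound 4, `C=NNc1nc2ccccc2nc1Cc1ccccc1`, has not yet been measured. Compared with compound 3 the change is a group of 2 heavy atoms (1 carbon, 1 nitrogen; no ring) in place of a group of 9 heavy atoms (7 carbon, 1 nitrogen, 1 bromine; one six-membered aromatic ring of carbon only), on a nitrogen on an aromatic ring. For the measured compounds named here, no measured step removes the ring at this position outright; the closest guidance comes from the two steps in which the group on that nitrogen was exchanged, a 20-fold lower number from compound 2 to compound 3 (1.31 log units; beyond the scatter) and a 12-fold higher number from compound 1 to compound 2 (1.07 log units; beyond the scatter), both large. Since the exchange of one six-membered aromatic ring for another already moved the number that far, the loss of the whole ring is expected to move it further in the weaker direction. For compound 4 a rise of roughly a 13-fold higher number from compound 3 to compound 4 (1.10 log units; beyond the scatter) is therefore expected, and compound 4 is estimated at 600000 nM, within a range of 120000 nM to 3000000 nM.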

Compound 4, half-maximal inhibitory concentration: 950000 nM
Compound 4: the middle estimate sits 1.6-fold (0.20 log units) below what was measured; the measured number falls inside the stated range.
By their numbers in this assay, from the lowest: compounds 3 and 1 (each within the scatter of the next); then compounds 4 and 2 (each within the scatter of the next).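

Read in this assay, replacing the aromatic ring of carbon only with the group of 2 heavy atoms and no ring now gives a direct measure of losing that ring at this position on the nitrogen, and the loss is large from both halogen-bearing compounds (a 20-fold higher number from compound 3 to compound 4 (1.30 log units; beyond the scatter)) (an 11-fold higher number from compound 1 to compound 4 (1.05 log units; beyond the scatter)). The ring with 1 hetero atom in compound 2 offers no measurable advantage over the ring-free group (a 1.0-fold lower number from compound 2 to compound 4 (0.01 log units; within the scatter)), so among these four compounds, having a six-membered aromatic ring at this position does not by itself separate compound 2 from compound 4. Nothing in the available information accounts for this difference between the rings.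

From the compounds shown here alone, it remains open whether the stronger numbers of compound 1 and compound 3 depend on the carbon-only ring alone or on its chlorine or bromine, a question that a plain phenyl group would address. Also open, going by these compounds, is how a ring carrying an amine or a carboxylic acid, or a longer alkyl chain with no ring, would behave at this position.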